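A Second Chloro on the Anilino Ring of Compound 2

The compounds below may be only part of what the source reports. "The series", "measured", "known", "first", "only" and "open" are said of these compounds alone.

The measured compounds:
compound 1, `c1ccc(Nc2ccc(N3CC4CC(C3)N4)nn2)cc1`, 441 nM
compound 2, `Clc1ccc(Nc2cncc(N3CC4CC(C3)N4)c2)cc1`, 0.118 nM
compound 3, `Clc1cccc(Nc2ccc(N3CC4CC(C3)N4)nn2)c1`, 1540 nM

In an assay on cell membranes for displacement of a labelled ligand from Neuronal acetylcholine receptor; alpha4/beta2 (Rattus norvegicus) (on this read-out lower numbers stand for stronger inhibition and higher numbers for weaker inhibition), compound 2 gives 0.118 nM, the lowest of the three numbers. Compound 1 and compound 2 share the diazabicyclic amine and the anilino group but are built on different cores; the difference between the two cores is not broken down here.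

From compound 1 to compound 3 the change is chloro in place of hydrogen on an aromatic carbon. The step it made is a 3.5-fold higher number from compound 1 to compound 3 (0.54 log units; beyond the scatter).

Compound 4, `Clc1ccc(Nc2cncc(N3CC4CC(C3)N4)c2)cc1Cl`, has not been measured. It differs from compound 2 by chloro in place of hydrogen on an aromatic carbon. This is the same kind of change as that from compound 1 to compound 3, but the place is not identical: in compound 4 the entering chloro sits ortho to a chloro group, whereas in compound 3 it does not.

Compound 4 is expected to show a 3.0-fold higher number from compound 2 to compound 4 (0.47 log units; beyond the scatter) in this assay, a step of the same modest kind as a 3.5-fold higher number from compound 1 to compound 3 (0.54 log units; beyond the scatter), because compound 1 gave 441 nM and compound 3 gave 1540 nM on a different core. The value for compound 4 is estimated at 0.35 nM, between 0.1 nM and 1.5 nM.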

Compound 4, inhibition constant: 1.25 nM
Compound 4: middle estimate off by 3.6-fold (0.55 log units), on the low side; measured number inside the range.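

The new step is an 11-fold higher number from compound 2 to compound 4 (1.03 log units; beyond the scatter), so in this assay the chloro moves the number the same way on the core of compound 2 as on the core of compound 1. The size of the step, however, did not carry over from one core to the other: the same change on two cores in this assay, a 3.5-fold higher number (0.54 log units; beyond the scatter) from compound 1 to compound 3 and an 11-fold higher number (1.03 log units; beyond the scatter) from compound 2 to compound 4, 3.0-fold (0.48 log units) apart, beyond the scatter of two such steps. These two pairs do not show that the core alone sets the size of the step, since the entering chloro sits ortho to a chloro group in compound 4 but not in compound 3, and the pairs cannot separate the core from the place.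

The compounds shown leave open how large the step would be with the chloro in the same place on both cores. As far as these compounds go, whether a methyl, a methoxy group or a nitrile in place of the entering chloro of compound 4 would move the number in the same way also remains open.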